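The source may hold more compounds than are shown below. What is called first, only, known or untested is meant among the compounds shown, and "the series" means these compounds.

Compound 1 `Cc1cc(S(=O)(=O)/N=C(\N)n2nccc2-c2ccccc2)c(SCc2ccccc2Cl)cc1Cl` stands second highest of the three numbers in a functional assay on MCF7 cells (Homo sapiens) for cytotoxicity, read by MTT assay, with a stated time of 72 h (on this read-out higher numbers stand for weaker inhibition and lower numbers for stronger inhibition), giving 24000 nM. Compound 3 `Cc1cc(S(=O)(=O)/N=C(\N)n2nccc2-c2ccccc2)c(SCc2ccccc2C)cc1Cl` gives 23000 nM, and a 1.0-fold lower number from compound 1 to compound 3 (0.02 log units; within the scatter), methyl in place of chloro on an aromatic carbon, is within the scatter. Compound 2 `Cc1cc(-c2ccccc2)n(/C(N)=N/S(=O)(=O)c2cc(C)c(Cl)cc2SCc2ccccc2C)n1` gives 80000 nM, and a 3.5-fold lower number from compound 2 to compound 3 (0.54 log units; beyond the scatter), hydrogen in place of methyl on an aromatic carbon, is beyond the scatter. Compound 4 `Cc1cc(S(=O)(=O)/N=C(\N)n2nccc2-c2ccccc2)c(SCc2cccc3ccccc23)cc1Cl` differs from compound 1 by naphthalen-1-yl in place of 2-chlorophenyl on a saturated chain carbon bound to a sulfur. For the measured compounds named here, only the step from compound 1 to compound 3 bears on this, as it also alters the 2-chlorophenyl group, and it was within the scatter; the change to naphthalen-1-yl is larger and has no precedent here, so at most a modest step is expected, direction uncertain. Compound 4 is expected at 20000 nM, range 6000 nM to 70000 nM, a step of a 1.2-fold lower number from compound 1 to compound 4 (0.08 log units; within the scatter).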

Compound 4, half-maximal inhibitory concentration: 58000 nM
For compound 4 the middle estimate is 2.9-fold (0.46 log units) below the measured one, and the stated range covers the measured number.
By their numbers in this assay, from the lowest: compounds 3 and 1 (each within the scatter of the next); then compounds 4 and 2 (each within the scatter of the next).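

For the compounds shown here, on the saturated chain carbon bound to a sulfur, naphthalen-1-yl gives the first change of the aryl group in this assay that lies beyond the scatter, toward weaker inhibition (a 2.4-fold higher number from compound 1 to compound 4 (0.38 log units; beyond the scatter); a 2.5-fold higher number from compound 3 to compound 4 (0.40 log units; beyond the scatter)). Methyl in place of chloro on that ring had stayed within the scatter (a 1.0-fold lower number from compound 1 to compound 3 (0.02 log units; within the scatter)), so this position tolerates that small exchange but not every aryl group equally. Nothing measured here gives a reason for the shift. Open, from the compounds shown here alone, is how an unsubstituted phenyl would compare with compound 4, which would separate the second ring from the loss of the chloro or methyl group. Also open, going by these compounds, is how an amine or a carboxylic acid on this chain would read.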